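From an Imidazole to a Triazole in Rat Liver Microsomes

This account rests on a few compounds, and the source may have more. Where it says the series, first, only, none or still open, it means among the compounds named here.

Measured so far:
Compound 1 `CC(C)C(Cc1ncc[nH]1)c1ccc(-c2ccc3cccc(F)c3c2)[nH]c1=O`: < 0.0667 h
Compound 2 `CCn1ncc2c(F)cc(-c3ccc(C(CC)(CC)c4nnc[nH]4)c(=O)[nH]3)cc21`: > 3 h

Of the compounds shown here, two have been measured in an ADME assay on microsomes from liver (Rattus norvegicus) for metabolic stability; on this read-out higher numbers stand for a longer-lived compound and lower numbers for a shorter-lived compound. Compound 1 gives < 0.0667 h, which is a limit of the assay and not a number (the limit of < 0.0667 h in this assay, at which 1 of the 2 values shown sits). Compound 2 gives > 3 h, again a limit rather than a number (the limit of > 3 h in this assay, at which 1 of the 2 values shown sits). Compound 1 therefore stands at the low edge of what this assay resolves, and compound 2 at the high edge. Within the data shown here, with only two limits and no pair that differs in a single place, there is no measured step that shows how far one change moves the half-life.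

Compound 3 `CC(C)C(Cc1nnc[nH]1)c1ccc(-c2ccc3cccc(F)c3c2)[nH]c1=O` is the compound still to be measured. It differs from compound 1 in one place: 4H-1,2,4-triazol-3-yl in place of 1H-imidazol-2-yl on a saturated chain carbon, two bonds along the chain from an aromatic carbon. Compound 2 also carries a 4H-1,2,4-triazol-3-yl group, but it differs from compound 1 in many other places, so its value cannot be read as the effect of this change alone. The step of an at least 2.2-fold higher number from compound 1 to compound 3 (0.35 log units; beyond the scatter) is expected to be a modest lengthening, somewhat beyond the scatter. Compound 3 is expected to give 0.15 h, within a range from 0.04 h to 0.6 h, with a real chance that the assay again reports only a limit.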

Compound 3, half-life: 0.1 h
Compound 3: middle estimate off by 1.5-fold (0.18 log units), on the high side; the range from low to high includes it.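

In this assay, putting 4H-1,2,4-triazol-3-yl in place of 1H-imidazol-2-yl on a saturated chain carbon, two bonds along the chain from an aromatic carbon, and leaving the rest of the molecule unchanged gives an at least 1.4-fold higher number from compound 1 to compound 3 (0.17 log units; that floor lies within the scatter). This is only a floor for the true step, and it cannot yet be called a change beyond the scatter, because the value of compound 1 is a limit and not a number: the limit of < 0.0667 h in this assay, at which 1 of the 3 values shown sits. What is new is that compound 3, at 0.1 h, gives a real number within the span this assay resolves, so the triazole at this position now has a measured half-life on the core of compound 1, though that half-life is still short.

On these data alone, how large the step really is stays open, and so does whether another group at this place, such as a carboxylic acid or a primary amine on the same chain carbon, would give a different half-life. Compound 2 differs from compound 3 in many places, so these compounds cannot tell which of its features go with its position at the high edge of this assay.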